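From amino to trifluoromethyl in a cytotoxicity series

The source may report more compounds than this note shows. Statements on the series, on what has been measured and on what is new or still open speak of the compounds shown alone.

In a functional assay on KB cells (Homo sapiens) for cytotoxicity, read by MTT assay, with a stated time of 72 h (a higher number here means a weaker inhibitor, a lower number a stronger inhibitor), compound 2 `O=S(=O)(c1ccc(Br)cc1)c1nc2ccccc2nc1Nc1ccccc1` gives 5100 nM and compound 3 `Nc1ccc(Nc2nc3ccccc3nc2S(=O)(=O)c2ccc(Br)cc2)cc1` gives 4080 nM. The measured step is a 1.3-fold lower number from compound 2 to compound 3 (0.10 log units; within the scatter), so compound 3 stands level with compound 2. Compound 1 `O=S(=O)(c1ccccc1)c1nc2ccccc2nc1Nc1ccc(C(F)(F)F)cc1`, which also carries trifluoromethyl, reads > 50000 nM, and this is a limit of the assay, not a number. Compound 4 `O=S(=O)(c1ccc(Br)cc1)c1nc2ccccc2nc1Nc1ccc(C(F)(F)F)cc1` has trifluoromethyl in place of the amino of compound 3 on an aromatic carbon (trifluoromethyl in place of amino on an aromatic carbon). Adding amino gave only a 1.3-fold lower number from compound 2 to compound 3 (0.10 log units; within the scatter), so losing it should matter little. Compound 1 at > 50000 nM still argues for caution towards a higher number. A modest rise is therefore expected in this assay, a 2.2-fold higher number from compound 3 to compound 4 (0.34 log units; beyond the scatter). For compound 4 the estimate is 9000 nM, with an expected range of 2500 nM to 40000 nM.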

Compound 4, half-maximal inhibitory concentration: > 50000 nM
Compound 4: a limit, no number; the forecaster's own chance of this, stated with the estimate: 20%; middle value at least 5.5-fold (0.74 log units) away from the limit.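

Trifluoromethyl on this aromatic carbon gives an at least 12-fold higher number from compound 3 to compound 4 (1.08 log units; beyond the scatter) and an at least 9.8-fold higher number from compound 2 to compound 4 (0.99 log units; beyond the scatter), so this position does respond to a change, although amino in place of hydrogen gave only a 1.3-fold lower number from compound 2 to compound 3 (0.10 log units; within the scatter). In this assay compound 4 reads as a limit and not a number, so both steps give only a minimum size: the limit of > 50000 nM in this assay, at which 2 of the 4 values shown sit. The step between compound 1 and compound 4 cannot be read, which leaves the effect of bromo here unknown.

Still open, on these data alone, is how a methoxy group or a carboxylic acid on this carbon would read, and so whether the weakening belongs to trifluoromethyl alone.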